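This account rests on a few compounds, and the source may have more. Where it says the series, first, only, none or still open, it means among the compounds named here.

Of the compounds shown here, two from this series have been measured, and they sit far apart. In a functional assay on DLD-1 cells (Homo sapiens) for antiproliferative activity, read by CellTiter-Glo, with a stated time of 72 h (on this read-out higher numbers stand for weaker inhibition and lower numbers for stronger inhibition), compound 1 `COc1ccccc1-c1cccc(S(=O)(=O)N2CCC(N3CCC(C)CC3)CC2)c1` gives 21 nM. Compound 2 `CC1CCN(C2CCN(S(=O)(=O)c3cccnc3Cl)CC2)CC1`, in contrast, reaches only the limit of the method, > 5000 nM, which is a ceiling of the measurement and not a number. On these data alone, that ceiling is the limit described by the limit of > 5000 nM in this assay, at which 1 of the 2 values shown sits, so where compound 2 truly stands above it is unknown.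

The next compound, compound 3 `CC1CCN(C2CCN(S(=O)(=O)c3ccc(Cl)c(Cl)c3)CC2)CC1`, is built on the same core as compound 2. The change is a single one: 3,4-dichlorophenyl in place of 2-chloropyridin-3-yl on a sulfonyl sulfur. Within the data shown here, no measured pair in this set shows the effect of this kind of swap, so the step from compound 2 to compound 3 can only be guessed. Since compound 2 already sits at the ceiling of this assay, the step is expected to go towards stronger inhibition, and its size is estimated as an at least 3.3-fold lower number from compound 2 to compound 3 (0.52 log units; beyond the scatter). On that basis compound 3 is expected to give about 1500 nM, somewhere between 200 nM and 8000 nM.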

Compound 3, half-maximal inhibitory concentration: 2.9 nM
Estimate against measurement, compound 3: 520-fold (2.71 log units) above; the whole stated range lies above it.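

The group on the sulfonyl sulfur has a very large influence on activity in this series: in this assay, 3,4-dichlorophenyl in place of 2-chloropyridin-3-yl gives an at least 1700-fold lower number from compound 2 to compound 3 (3.23 log units; beyond the scatter). On these data alone, for compound 2, > 5000 nM is a limit and not a number, so the true size of this step remains unknown: the limit of > 5000 nM in this assay, at which 1 of the 3 values shown sits A low value does not depend on the group found in compound 1: compound 3 gives 2.9 nM, and compound 1, with a different aromatic group at this place, gives 21 nM.

This swap changes the ring nitrogen and the chlorines together, so the compounds shown cannot tell which of these changes matters. As far as these compounds go, how a carboxylic acid or an amine on this aromatic ring would behave also remains open.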